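From Isopropoxy to Hydrogen on the Aromatic Ring

A few compounds are considered here, and "the series" means these few. Any claim that something is new, unique, unknown or untested is made for them only; others in the source may bear on it.

compound 1 `CC[C@H](C)Oc1ccccc1CNC(=O)c1ccc2cnccc2n1`: 3.1 ug/mL
compound 2 `CC(C)Oc1cccc(CNC(=O)c2ccc3cnccc3n2)c1`: 8.4 ug/mL

Only these two compounds have been measured in a functional assay on Hs68 cells (Homo sapiens) for cytotoxicity; a higher number here means that more compound is tolerated, a lower number that less compound is tolerated. Of the pair, compound 2 stands highest at 8.4 ug/mL, and compound 1 gives 3.1 ug/mL, a gap beyond the usual scatter. The next compound to be tested is compound 3 `O=C(NCc1ccccc1)c1ccc2cnccc2n1`, which carries hydrogen in place of isopropoxy on an aromatic carbon, meta to a large group (hydrogen in place of isopropoxy on an aromatic carbon). Going by the values given here, no measured pair shows this change on its own, so the expectation is uncertain. In this assay, a moderate rise beyond the scatter is expected, meaning that more compound would be tolerated. The expected change is a 2.1-fold higher number from compound 2 to compound 3 (0.33 log units; beyond the scatter). The estimate for compound 3 is 18 ug/mL, with an expected range from 6 ug/mL to 60 ug/mL.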

Compound 3, half-maximal cytotoxic concentration: 71 ug/mL
Compound 3: middle estimate off by 3.9-fold (0.60 log units), on the low side, outside the stated range (above it).
By their numbers in this assay, from the lowest: compound 1; then compound 2; then compound 3.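

In this assay, going by these compounds alone, replacing isopropoxy with hydrogen on the aromatic carbon gives an 8.5-fold higher number from compound 2 to compound 3 (0.93 log units; beyond the scatter), the first reading of a single change at this position. Replacing sec-butoxy with hydrogen gives a 23-fold higher number from compound 1 to compound 3 (1.36 log units; beyond the scatter), so both ether-bearing compounds are tolerated less well than the compound with hydrogen, and neither goes against this within the three compounds. Nothing measured here accounts for the size of these steps.

As far as these compounds go, it remains open whether a smaller group on this carbon, such as methoxy or hydroxyl, would keep the number near that of compound 3 or bring it back towards that of compound 2. The compounds shown also leave open how an amine or a carboxylic acid at this carbon would compare with hydrogen.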